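Antiproliferative activity: from compound 3 to compound 4

The source may report more compounds than this note shows. Statements on the series, on what has been measured and on what is new or still open speak of the compounds shown alone.

Measured compounds and their readings:
- Compound 1, `Cc1cccc(NC(=O)Nc2cccc(CNc3ncnc4ccccc34)c2)c1`: in a functional assay on HepG2 cells (Homo sapiens) for antiproliferative activity, read by MTT assay (a lower number here means a stronger inhibitor, a higher number a weaker inhibitor), compound 1 gives only a limit of the assay, > 50000 nM.
- Compound 2, `O=C(Nc1cccc(CNc2ncnc3ccccc23)c1)Nc1ccccc1Cl`: in this assay compound 2 gives only a limit, > 50000 nM.
- Compound 3, `COc1cc2ncnc(NCc3cccc(NC(=O)Nc4ccccc4C)c3)c2cc1OC`: in this assay compound 3 also gives only a limit, > 50000 nM.

None of the three readings is a number; each is the limit at which the assay stops reporting, and the limit of > 50000 nM in this assay, at which 3 of the 3 values shown sit, states that every value shown sits there. Compound 3 therefore stands at that limit, with no finer position among the compounds shown. Going by the values given here, the only measured step between two compounds differing in one place, a step that the two limits leave unreadable from compound 1 to compound 2, cannot be sized, since both ends are limits.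

The change to compound 4, `COc1cc2ncnc(NCc3cccc(NC(=O)Nc4cccc(C(F)(F)F)c4)c3)c2cc1OC`, is 3-(trifluoromethyl)phenyl in place of 2-methylphenyl on an amide-type nitrogen. Among the compounds with values here, no measured step bears on this exchange, and the one step that exists is unreadable. Nothing in the data points to a gain beyond the scatter, so compound 4 is expected to stay where compound 3 stands, with the expected step of a number no higher from compound 3 to compound 4 (the limit leaves the size open). The estimate for compound 4 in this assay is 50000 nM, with a range from 15000 nM to 150000 nM, and most likely the assay again reports only a limit.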

Compound 4, half-maximal inhibitory concentration: 34200 nM
Estimate against measurement, compound 4: 1.5-fold (0.16 log units) above, and the stated range covers the measured number.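

In this assay compound 4 gives 34200 nM, the only actual number among the compounds shown, so this place on the amide-type nitrogen now has one reading that is not a limit of the assay. Going by these compounds, putting 3-(trifluoromethyl)phenyl in place of 2-methylphenyl gives an at least 1.4-fold lower number from compound 3 to compound 4 (0.16 log units; that floor lies within the scatter); this is only a floor and not a full size, since the reading of compound 3 is a limit, and the true distance between the two compounds stays unknown. The earlier step between two limits cannot be read, so this is the first step at this position with any readable size, yet the single number still stands alone among the limits: the limit of > 50000 nM in this assay, at which 3 of the 4 values shown sit.

The compounds shown leave open whether the reading of compound 4 depends on the trifluoromethyl group itself, since a nitrile, a carboxylic acid or an amine on the same phenyl ring would be needed to tell. They also leave open whether 3-(trifluoromethyl)phenyl would give a number on the core of compound 1, or whether the methoxy groups of compound 4 are needed as well.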